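Swapping Methoxy for Trifluoromethyl on a Hydrazone

The source may hold more compounds than are shown below. What is called first, only, known or untested is meant among the compounds shown, and "the series" means these compounds.

Measured compounds:
compound 1 `COc1cccc(NN=C2C(Cl)=C(Cl)C(Cl)=C2Cl)c1` gives > 3000 nM
compound 2 `C#CC(C)(C)OC(=O)NN=C1C(Cl)=C(Cl)C(Cl)=C1Cl` gives "not determined" (no result reported)
compound 3 `ClC1=C(Cl)C(Cl)=C(Cl)C1=NN(c1ccccc1)c1ccccc1` gives > 3000 nM

The readout throughout is a functional assay on MM1.S cells (Homo sapiens) for cytotoxicity, read by MTT assay, with a stated time of 48 h; a higher number here means a weaker inhibitor, a lower number a stronger inhibitor. Compound 1 does not return a number in this assay: its value of > 3000 nM is a limit of the assay, meaning the compound was too weak to register within the tested range. Compound 3 sits at the same limit, with > 3000 nM, again a limit rather than a measured number. For compound 2 no result is reported, so only compound 1 and compound 3 give any information, and both sit at the limit of > 3000 nM in this assay, at which 2 of the 3 values shown sit. Compound 1 therefore stands at the weak end of what the assay can report, not above any other compound.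

The compound still to be measured is compound 4 `FC(F)(F)c1cccc(NN=C2C(Cl)=C(Cl)C(Cl)=C2Cl)c1`. It differs from compound 1 by trifluoromethyl in place of methoxy on an aromatic carbon. Among the compounds with values here, no pair of measured compounds shows what such a change does to potency here, so the expected step from compound 1 to compound 4 is a number no higher from compound 1 to compound 4 (the limit leaves the size open), which is no step beyond the usual scatter. Compound 4 is therefore expected to give about 3000 nM, within a range of 800 nM to 12000 nM, and it is more likely than not that this assay will again report only a limit.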

Compound 4, half-maximal inhibitory concentration: 1000 nM
For compound 4 the middle estimate is 3.0-fold (0.48 log units) above the measured one; the measured number falls inside the stated range.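

Among the compounds shown, compound 4 is the only one to give an actual number in this assay, so this change, on an aromatic carbon meta to a large group, brings the series into the range where potency can be read, whereas the earlier results marked only the assay's limit: the limit of > 3000 nM in this assay, at which 2 of the 4 values shown sit.

Trifluoromethyl in place of methoxy gives an at least 3.0-fold lower number from compound 1 to compound 4 (0.47 log units; beyond the scatter), and the value of compound 1 is a limit, so the true size of the step stays open. This single pair shows that the group at this one place can matter in these cells, but it cannot establish a trend.

The compounds shown do not tell why the swap helps, nor whether the result comes from losing methoxy, from gaining trifluoromethyl, or from both. They also leave open whether a nitrile, an amine or a carboxylic acid on the same carbon would move the number further, and whether trifluoromethyl would do the same on another carbon of the ring.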